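Swapping methyl for cyano on the outer aromatic ring

The source may report more compounds than this note shows. Statements on the series, on what has been measured and on what is new or still open speak of the compounds shown alone.

Compound 1 `Cc1cc(-c2cccc(Cl)c2)cc(C)c1Oc1cc(N)nc(Nc2ccc(C#N)cc2)n1` gives 22300 nM
Compound 2 `Cc1cc(-c2ccc(Cl)cc2)cc(C)c1Oc1cc(N)nc(Nc2ccc(C#N)cc2)n1` gives 21500 nM
Compound 3 `Cc1ccc(-c2cc(C)c(Oc3cc(N)nc(Nc4ccc(C#N)cc4)n3)c(C)c2)cc1` gives 10000 nM

In a toxicity assay on MT4 cells (Homo sapiens) for cytotoxicity, read by MTT assay (on this read-out lower numbers stand for higher toxicity in this test and higher numbers for lower toxicity in this test), compound 3 stands at 10000 nM, the lowest of the three numbers. Compound 4 `Cc1cc(-c2ccc(C#N)cc2)cc(C)c1Oc1cc(N)nc(Nc2ccc(C#N)cc2)n1` has not yet been measured. Its structure departs from that of compound 3 by one change, (cyano in place of methyl on an aromatic carbon), with cyano in place of methyl on an aromatic carbon, para to a large group.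

For the measured compounds named here, no measured step places cyano there, so the evidence is indirect. The closest change, methyl in place of chloro on an aromatic carbon, gave a 2.2-fold lower number from compound 2 to compound 3 (0.33 log units; beyond the scatter). The change between the two chlorinated compounds gave a 1.0-fold lower number from compound 1 to compound 2 (0.02 log units; within the scatter). These steps are small, and compound 3 already holds the lowest number, so no step beyond the scatter is expected in this assay, only a slight lean towards a higher number. The expected change is a 1.5-fold higher number from compound 3 to compound 4 (0.18 log units; within the scatter). For compound 4 the estimated value is 15000 nM, within an expected range of 6000 nM to 40000 nM.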

Compound 4, half-maximal cytotoxic concentration: 18100 nM
Beside the measured number, compound 4's estimate is 1.2-fold (0.08 log units) below it; the range from low to high includes it.
By their numbers in this assay, from the lowest: compounds 3, 4, 2 and 1 (each within the scatter of the next, the first and the last beyond it).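

In this assay, cyano in place of methyl on this aromatic carbon, para to a large group, stays within the scatter (a 1.8-fold higher number from compound 3 to compound 4 (0.26 log units; within the scatter)), and cyano in place of chloro does the same (a 1.2-fold lower number from compound 2 to compound 4 (0.07 log units; within the scatter)). The 4-cyanophenyl group is also not separated from the 3-chlorophenyl group (a 1.2-fold lower number from compound 1 to compound 4 (0.09 log units; within the scatter)). So compound 4, the only one with a nitrile on the outer ring, cannot be told apart from any of the other three, even though the step from chloro to methyl had gone beyond the scatter, which means this change adds no clear step at this position.

Going by these compounds, how an amine or a carboxylic acid on the same carbon would read in this test stays open. The data offer no explanation for any of these numbers.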